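Chain extension on the deprotected core of compound 3

A few compounds are considered here, and "the series" means these few. Any claim that something is new, unique, unknown or untested is made for them only; others in the source may bear on it.

Compound 1 `CCCCCC#Cc1cn(CCC(COC(C)=O)COC(C)=O)c(=O)n(C(=O)c2ccccc2)c1=O` and compound 2 `CCCCCCCCC#Cc1cn(CCC(COC(C)=O)COC(C)=O)c(=O)n(C(=O)c2ccccc2)c1=O` share one core; compound 3 `CCCCCC#Cc1cn(CCC(CO)CO)c(=O)[nH]c1=O` and compound 4 `CCCCCCCCC#Cc1cn(CCC(CO)CO)c(=O)[nH]c1=O` share another. The difference between the two cores is not broken down here. In a functional assay on SW-620 cells (Homo sapiens) for antiproliferative activity, read by MTT assay, with a stated time of 72 h (on this read-out lower numbers stand for stronger inhibition and higher numbers for weaker inhibition), compound 1 gives 40700 nM. Compound 2 gives 65800 nM in this assay. The change propyl in place of hydrogen on a saturated chain carbon, five bonds along the chain from a triple-bonded carbon thus made a 1.6-fold higher number from compound 1 to compound 2 (0.21 log units; within the scatter). For compound 3 this assay reports only a limit, > 100000 nM, namely (the limit of > 100000 nM in this assay, at which 1 of the 3 values shown sits). Compound 4 carries the same change, (propyl in place of hydrogen on a saturated chain carbon, five bonds along the chain from a triple-bonded carbon), on the core of compound 3. Because compound 3 already sits at the limit of > 100000 nM in this assay, at which 1 of the 3 values shown sits, compound 4 is expected to be reported as a limit as well. The step expected here, a step that the limit leaves unreadable from compound 3 to compound 4, is an estimate resting on a 1.6-fold higher number from compound 1 to compound 2 (0.21 log units; within the scatter). Compound 4 is estimated at 150000 nM in this assay, within 60000 nM to 400000 nM.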

Compound 4, half-maximal inhibitory concentration: > 100000 nM
Compound 4 ended at the assay's limit; the forecaster's own chance of this, stated with the estimate: 75%; the middle value is on the limit's open side.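

No step can be read from compound 3 to compound 4, because both are reported only as limits in this assay: the limit of > 100000 nM in this assay, at which 2 of the 4 values shown sit.

Still open, on these data alone, is whether propyl in place of hydrogen changes antiproliferative activity on the core of compound 3.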